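A few compounds are considered here, and "the series" means these few. Any claim that something is new, unique, unknown or untested is made for them only; others in the source may bear on it.

The measured compounds and their numbers:

Compound 1, `CCCCCCCC(=O)O[C@H]1[C@H](O)[C@H](n2ccc(N)nc2=O)O[C@@H]1CO`, gives 0.1 ug/mL.
Compound 2, `CCCCCC(=O)OC[C@H]1O[C@@H](n2ccc(N)nc2=O)[C@@H](O)[C@@H]1OC(=O)CCCCC`, gives 0.07 ug/mL.
Compound 3, `CCCCCCCCCCCCCCCCCC(=O)O[C@H]1[C@H](O)[C@H](n2ccc(N)nc2=O)O[C@@H]1CO`, gives 0.13 ug/mL.

All three were tested in a functional assay on HeLa cells (Homo sapiens) for cytotoxicity, read by cell counting, with a stated time of 48 h; a higher number here means that more compound is needed for the effect, a lower number that less compound is needed. Compound 3 has the highest of the three numbers, but its neighbours are close: compound 1 is within the scatter of it, and compound 2 is within the scatter of it as well, so no order among the three can be read from these values.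

Compound 4, `CCCCCC(=O)O[C@H]1[C@H](O)[C@H](n2ccc(N)nc2=O)O[C@@H]1CO`, shares the core of compound 3 and differs from it in one place: hydrogen in place of dodecyl on a saturated chain carbon, five bonds along the chain from a carbonyl carbon. Among the compounds with values here, the only measured step that bears on this change is the one on the same chain, a 1.3-fold higher number from compound 1 to compound 3 (0.11 log units; within the scatter), where the addition of decyl left the number within the scatter. That step points to a chain whose length, over the span covered so far, barely moves the read-out of this assay. Within the data shown here, removing dodecyl is a change of the same kind, and no step in the data suggests a different outcome, so the step from compound 3 to compound 4 is expected to be small, a 1.2-fold higher number from compound 3 to compound 4 (0.06 log units; within the scatter), with no direction beyond the scatter claimed. On this basis compound 4 is estimated at 0.15 ug/mL, within a range from 0.05 ug/mL to 0.5 ug/mL.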

Compound 4, concentration for half-maximal effect: 0.05 ug/mL
The estimate for compound 4 lay 3.0-fold (0.48 log units) above the measured number; the range from low to high includes it.
By their numbers in this assay, from the lowest: compounds 4, 2, 1 and 3 (each within the scatter of the next, the first and the last beyond it).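

In this assay, within the data shown here, hydrogen in place of dodecyl on a saturated chain carbon, five bonds along the chain from a carbonyl carbon, gives the first step in this set that lies beyond the scatter (a 2.6-fold lower number from compound 3 to compound 4 (0.41 log units; beyond the scatter)), though only a modest one, whereas the earlier step on the same chain stayed within it (a 1.3-fold higher number from compound 1 to compound 3 (0.11 log units; within the scatter)). The smaller change at this position, hydrogen in place of ethyl, remains within the scatter (a 2.0-fold lower number from compound 1 to compound 4 (0.30 log units; within the scatter)), so among compounds 1, 3 and 4 the chain makes a readable difference only when the whole dodecyl group leaves. Hydrogen in place of pentylcarbonyl on an oxygen on a saturated carbon also leaves the number within the scatter (a 1.4-fold lower number from compound 2 to compound 4 (0.15 log units; within the scatter)), so compound 4 cannot be ranked against compound 2.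

The compounds shown leave open whether an amine or a carboxylic acid at the end of the chain, or a chain shorter than the one in compound 4, would move the number in this assay at all. Nothing available here accounts for the step from compound 3 to compound 4.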